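From compound 3 to compound 4: a naphthalen-1-yl swap

This account rests on a few compounds, and the source may have more. Where it says the series, first, only, none or still open, it means among the compounds named here.

Results so far in a functional assay on HeLa cells (Homo sapiens) for inhibition, read by CCK-8 assay, with a stated time of 72 h, tested at 8 uM (a higher number here means more inhibition of growth at the concentration tested, a lower number less inhibition of growth), are as follows
Compound 1 `Nc1ccccc1NC(=O)/C=C/c1ccc(CSc2cccc(F)c2)cc1` gives 18.6%
Compound 2 `CCc1ccc(SCc2ccc(/C=C/C(=O)Nc3ccccc3N)cc2)cc1` gives 20.9%
Compound 3 `Nc1ccccc1NC(=O)/C=C/c1ccc(CSc2ccc(C(F)(F)F)cn2)cc1` gives 6.82%

Compound 3 stands lowest of the three, and its value of 6.82% lies beyond the scatter from both others. Compound 4 `Nc1ccccc1NC(=O)/C=C/c1ccc(CSc2cccc3ccccc23)cc1` keeps the shared core and changes one group on a sulfur whose other neighbour is a saturated chain carbon: naphthalen-1-yl in place of 5-(trifluoromethyl)pyridin-2-yl on a sulfur. The entering group has aromatic rings of carbon only, as do the groups of compound 1 and compound 2, which differ little: a number 2.3 percentage points higher from compound 1 to compound 2 (within the scatter). Among the measured compounds shown here, two measured steps bear on the change, a number 11.8 percentage points lower from compound 1 to compound 3 (beyond the scatter) and a number 14.1 percentage points lower from compound 2 to compound 3 (beyond the scatter). Both are modest and both enter the group that compound 4 gives up, so leaving it should reverse them in part or in full. For the measured compounds named here, no measured compound carries two fused rings, which leaves the estimate uncertain. The expected change is a modest rise, estimated as a number 11.2 percentage points higher from compound 3 to compound 4 (beyond the scatter) in size. For compound 4 the estimated value in this assay is 18% with an expected range from 7% to 32% for repeat measurements.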

Compound 4, percent growth inhibition at one concentration: 22.1%
The estimate for compound 4 lay 4.1 percentage points below the measured number; measured number inside the range.
By their numbers in this assay, from the lowest: compound 3; then compounds 1, 2 and 4 (each within the scatter of the next).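

In this assay, naphthalen-1-yl on the sulfur brings a clear gain over the 5-(trifluoromethyl)pyridin-2-yl group, with a number 15.3 percentage points higher from compound 3 to compound 4 (beyond the scatter). The comparisons with the single-ring groups give a number 1.2 percentage points higher from compound 2 to compound 4 (within the scatter) and a number 3.5 percentage points higher from compound 1 to compound 4 (within the scatter), so the second fused ring of carbon sets compound 4 apart from neither compound 2 nor compound 1, and among these four compounds only compound 3, the one with nitrogen in its ring, stands apart. No measurement here explains this difference.

Compound 3 differs from the others in both its ring nitrogen and its trifluoromethyl group, so the compounds shown cannot tell which of the two goes with its lower number. A plain pyridin-2-yl group and a phenyl ring carrying trifluoromethyl would each separate these two features.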